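Para substitution on the benzylidene aryl of the shared core

The compounds below may be only part of what the source reports. "The series", "measured", "known", "first", "only" and "open" are said of these compounds alone.

Compound 1 `CN(CC1CCC/C(=C\c2ccccc2)C1=O)c1ccccc1` carries a hydrogen on the aromatic carbon in question and in a functional assay on the whole organism (Ear, strain Kunming) for inhibition, with Mus musculus as the target, with stated times of 1 h and 30 min, at a dose of 200 mg/kg by the oral route (a lower number here means less inhibition, a higher number more inhibition at the dose given (going by the name of the read-out)), compound 1 gives 49.7%. For the measured compounds named here, compound 2 `Cc1ccc(/C=C2\CCCC(CN(C)c3ccccc3)C2=O)cc1` bears a methyl at that place and in this assay compound 2 gives 39.5%, the lowest of the two numbers so far; the only step available is a number 10.2 percentage points lower from compound 1 to compound 2 (beyond the scatter). Compound 3 `CN(CC1CCC/C(=C\c2ccc(S(C)(=O)=O)cc2)C1=O)c1ccccc1` differs from compound 2 by methylsulfonyl in place of methyl on an aromatic carbon. Going by the values given here, no measured step exchanges a methyl for a methylsulfonyl, so the one step that bears on the change is only that from compound 1 to compound 2, which shows that a small change at this carbon shifts the read-out modestly. A step of comparable size in either direction is therefore plausible, and the expectation for compound 3 is a number 5.5 percentage points higher from compound 2 to compound 3 (within the scatter), which is expected to lie within the scatter. Compound 3 is thus estimated at 45%, expected between 25% and 65%.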

Compound 3, a percentage reported as inhibition, in the whole organism at one dose (the size of the read-out at that dose, not a potency): 46.9%
Estimate against measurement, compound 3: 1.9 percentage points below; low and high end bracket the measured number.
By their numbers in this assay, from the lowest: compounds 2, 3 and 1 (each within the scatter of the next, the first and the last beyond it).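

In this assay, methylsulfonyl in place of methyl on this aromatic carbon gives a number 7.4 percentage points higher from compound 2 to compound 3 (within the scatter), and methylsulfonyl in place of hydrogen gives a number 2.8 percentage points lower from compound 1 to compound 3 (within the scatter). Compound 3 therefore cannot be told apart from either neighbour, so this carbon, para to a large group, accepts a group of several heavy atoms with hydrogen-bond acceptors without a step beyond the scatter, and the only such step among these compounds remains the one between the hydrogen and the methyl. No measurement bears on what lies behind these numbers.

As far as these compounds go, whether an amine or a carboxylic acid on this aromatic carbon would move the read-out beyond the scatter stays open. Also open, from the compounds shown here alone, is whether methylsulfonyl would give a similar number elsewhere on this six-membered aromatic ring.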